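The compounds below may be only part of what the source reports. "The series", "measured", "known", "first", "only" and "open" are said of these compounds alone.

Measured compounds and their values:
compound 1 `Nc1nc(NCc2ccccc2)c2ncn(/C=C3/CC3(CO)CO)c2n1` — > 20000 nM
compound 2 `CCCCCOc1nc(N)nc2c1ncn2/C=C1/CC1(CO)CO` — > 20000 nM
compound 3 `Nc1nc(N2CCCC2)c2ncn(/C=C3/CC3(CO)CO)c2n1` — "not determined" (no result reported)

In an ADME assay on MOLT-3 cells (Homo sapiens) for cytotoxicity, with a stated time of 7 days (a higher number here means that more compound is tolerated, a lower number that less compound is tolerated), compound 1 reaches only a limit of the assay, > 20000 nM, and not a number. Compound 2 likewise ends at a limit in this assay, > 20000 nM. The step that the two limits leave unreadable from compound 1 to compound 2 therefore cannot be read, since both ends are limits. For compound 3 no result in this assay is reported: "not determined" (no result reported). So compound 3 stands nowhere on the numbers shown; it carries no value of its own.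

Compound 4 `CCOc1nc(N)nc2c1ncn2/C=C1/CC1(CO)CO` follows from compound 3 by one change: ethoxy in place of pyrrolidin-1-yl on an aromatic carbon. Among the compounds with values here, no measured step bears on this change, and the single step that exists is unreadable. What can be said rests on the limit of > 20000 nM in this assay, at which 2 of the 3 values shown sit: both compounds that were measured sit at that limit, which makes a result at the limit the most likely outcome for compound 4 as well. Compound 4 is therefore expected to give 25000 nM, within 10000 nM to 60000 nM, most probably again as a limit.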

Compound 4, half-maximal cytotoxic concentration: > 20000 nM
Compound 4: no number, only a limit; the forecaster's own chance of this, stated with the estimate: 80%; the middle value does not contradict the limit.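

The steps from compound 2 and from compound 1 to compound 4 cannot be read, since each of these three compounds gives a limit and not a number in this assay: the limit of > 20000 nM in this assay, at which 3 of the 4 values shown sit. The compounds shown leave open whether swapping the group on the aromatic carbon changes cytotoxicity at all.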